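A Sulfonamide in Place of a Propyl Chain

The compounds below may be only part of what the source reports. "The series", "measured", "known", "first", "only" and "open" are said of these compounds alone.

Measured compounds:
Compound 1, `Cc1ccc(-c2cn(C/C=C3\OC(=O)C(OCc4ccccc4)=C3OCc3ccccc3)nn2)cc1`, in a functional assay on HepG2 cells (Homo sapiens) for antiproliferative activity, read by MTT assay, with a stated time of 72 h (a higher number here means a weaker inhibitor, a lower number a stronger inhibitor), gives > 100000 nM, which is a limit of the assay.
Compound 2, `CCCCc1cn(C[C@H](O)[C@H]2OC(=O)C(OCc3ccccc3)=C2OCc2ccccc2)nn1`, in this assay gives 32800 nM.
Compound 3, `COc1ccc(-c2cn(C/C=C3\OC(=O)C(OCc4ccccc4)=C3OCc3ccccc3)nn2)cc1`, in this assay gives > 100000 nM, again a limit of the assay.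

Among the measured compounds shown here, compound 2 therefore stands as the only compound of the three with a number in this assay; the other two sit at the limit of > 100000 nM in this assay, at which 2 of the 3 values shown sit. For the measured compounds named here, the single step between measured compounds, a step that the two limits leave unreadable from compound 1 to compound 3, cannot be read in size, since both of its ends lie at the limit of > 100000 nM in this assay, at which 2 of the 3 values shown sit.

Compound 4, `O=C1O[C@H]([C@@H](O)Cn2cc(CNS(=O)(=O)c3ccc(Cl)cc3)nn2)C(OCc2ccccc2)=C1OCc1ccccc1`, differs from compound 2 by ((4-chlorophenyl)sulfonyl)amino in place of propyl on a saturated chain carbon bound to an aromatic carbon. No measured step touches this kind of change, and the one step that is shown gives no size. With nothing to lean on, the expectation is that the value of compound 2 carries over, and the expected step is a 1.1-fold lower number from compound 2 to compound 4 (0.04 log units; within the scatter), which is no change beyond the scatter. Compound 4 is estimated at 30000 nM, with a range from 7000 nM to 100000 nM.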

Compound 4, half-maximal inhibitory concentration: 7510 nM
Compound 4: the middle estimate sits 4.0-fold (0.60 log units) above what was measured; the measured number falls inside the stated range.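

Among the compounds shown here, on the saturated chain carbon bound to an aromatic carbon, ((4-chlorophenyl)sulfonyl)amino in place of propyl gives the first step of readable size in this assay, a 4.4-fold lower number from compound 2 to compound 4 (0.64 log units; beyond the scatter). This position therefore takes a larger group carrying an aromatic ring and a hydrogen-bond donor without any loss, and the number moves modestly towards stronger inhibition. The earlier compounds could not show this, as compound 1 and compound 3 both sit at a limit of the assay and the one step between them cannot be read: the limit of > 100000 nM in this assay, at which 2 of the 4 values shown sit.

On these data alone, it remains open whether this step belongs to the sulfonyl amino link or to the 4-chlorophenyl ring. A simple amine, a carboxylic acid or a longer alkyl chain at the same place would help to tell how much of it depends on either part.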